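A few compounds are considered here, and "the series" means these few. Any claim that something is new, unique, unknown or untested is made for them only; others in the source may bear on it.

Compounds measured in a functional assay on MCF7 cells (Homo sapiens) for inhibition, read by CCK-8 assay, with a stated time of 48 h; on this read-out higher numbers stand for weaker inhibition and lower numbers for stronger inhibition:
- compound 1, `COc1ccc(-c2cc3nccc(-c4cc(OC)c(OC)c(OC)c4)n3n2)cc1[N+](=O)[O-]`: > 10000 nM.
- compound 2, `COc1ccc(-c2cc3nccc(-c4cc(OC)c(OC)c(OC)c4)n3n2)cc1F`: 183 nM.
- compound 3, `COc1cc(-c2ccnc3cc(-c4ccc(-c5cnn(C)c5)cc4)nn23)cc(OC)c1OC`: 274 nM.

For compound 1 the value of > 10000 nM is a limit of this assay, not a number. Compound 2 gives the smaller of the two numbers in this assay, yet compound 3 lies within the usual scatter of it, so the two cannot be set in order. Among the compounds with values here, the one step computed between measured compounds is an at least 54-fold lower number from compound 1 to compound 2 (1.73 log units; beyond the scatter), with fluoro in place of nitro on an aromatic carbon; its size rests on (the limit of > 10000 nM in this assay, at which 1 of the 3 values shown sits).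

Compound 4, `COc1cc(-c2ccnc3cc(-c4cccc(C)c4)nn23)cc(OC)c1OC`, is not yet measured. It differs from compound 2 by 3-methylphenyl in place of 3-fluoro-4-methoxyphenyl on an aromatic carbon. The step from compound 1 to compound 2 shows that the substitution of this aryl group can move the number strongly, while compound 3, carrying a quite different aryl at the same place, sits within the scatter of compound 2. The step is therefore expected to be small: a 1.9-fold higher number from compound 2 to compound 4 (0.28 log units; within the scatter), leaning toward a somewhat higher number. Compound 4 is estimated at 350 nM in this assay, with an expected range from 120 nM to 1000 nM.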

Compound 4, half-maximal inhibitory concentration: 1080 nM
Compound 4: the middle estimate sits 3.1-fold (0.49 log units) below what was measured, outside the stated range (above it).
By their numbers in this assay, from the lowest: compounds 2 and 3 (each within the scatter of the next); then compound 4. At a limit, above all of these: compound 1.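

In this assay the exchange gives a 5.9-fold higher number from compound 2 to compound 4 (0.77 log units; beyond the scatter) and so shows that the aryl group on this aromatic carbon matters even with no nitro involved. Within the data shown here, the only earlier step at this place had a limit at one end, whereas this one joins two measured numbers and is modest in size. It replaces the whole 3-fluoro-4-methoxyphenyl at once, so it cannot be divided among the loss of the fluoro, the loss of the methoxy and the arrival of the methyl, and nothing given here bears on what lies behind it.

The compounds shown leave open how a 3-fluorophenyl or a 4-methoxyphenyl would stand here, each carrying only one of the two departing groups. They also leave open what an amine or a carboxylic acid on this aryl ring would do.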